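This account rests on a few compounds, and the source may have more. Where it says the series, first, only, none or still open, it means among the compounds named here.

Of the compounds shown here, two that share one core have so far been measured in a functional assay on the whole organism (Tail, strain ICR) with Mus musculus as the target, in the tail flick test, with a stated time of 90 min, at a dose of 25 umol/kg by the oral route; on this read-out lower numbers stand for a weaker effect and higher numbers for a stronger effect at the one dose given. Compound 1 `O=C(CN(c1ncnc2c1ncn2C1CCCCO1)C1CC1)N[C@@H](CCC(=O)OCc1ccccc1)C(=O)OCc1ccccc1` gives 25.2% in this assay. Compound 2 `C[C@H](NC(=O)CN(c1ncnc2c1ncn2C1CCCCO1)C1CC1)C(=O)OCc1ccccc1` gives 32.1% in this assay. For the measured compounds named here, the one step between them, a number 6.9 percentage points higher from compound 1 to compound 2 (within the scatter), is the replacement of (benzyloxycarbonyl)methyl by hydrogen on a saturated chain carbon, two bonds along the chain from an amide-type nitrogen and a carbonyl carbon. The two numbers therefore lie within the scatter of each other, and on the numbers shown compound 2 cannot be set apart from compound 1.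

Compound 3 `CC(C)(C)OC(=O)NCCCC[C@H](NC(=O)CN(c1ncnc2c1ncn2C1CCCCO1)C1CC1)C(=O)OCc1ccccc1` has not yet been measured. It differs from compound 2 by 3-((tert-butoxycarbonyl)amino)propyl in place of hydrogen on a saturated chain carbon, two bonds along the chain from an amide-type nitrogen and a carbonyl carbon, at the same place where compound 1 and compound 2 differ. Going by the values given here, because a number 6.9 percentage points higher from compound 1 to compound 2 (within the scatter) is the only step measured at this place and stayed within the scatter, a change at this place is expected to leave the number close to where it is. Among the compounds with values here, no measured pair shows the effect of a longer chain carrying a hydrogen-bond donor there. Compound 3 is expected to show a step of a number 4.1 percentage points lower from compound 2 to compound 3 (within the scatter). The estimate for compound 3 in this assay is 28%, within a range from 12% to 45%.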

Compound 3, a percentage reported as activity, at one dose (the size of the read-out at that dose, not a potency): 32.9%
Compound 3: middle estimate off by 4.9 percentage points, on the low side; low and high end bracket the measured number.
By their numbers in this assay, from the lowest: compounds 1, 2 and 3 (each within the scatter of the next).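

In this assay, the earlier pair showed only one side chain swapped for hydrogen, and compound 3 now tests a second, quite different one at the same place: 3-((tert-butoxycarbonyl)amino)propyl, with 11 heavy atoms, one hydrogen-bond donor and two hydrogen-bond acceptors, enters in place of hydrogen, giving a number 0.8 percentage points higher from compound 2 to compound 3 (within the scatter). The two side chains can also be compared directly, with 2-((tert-butoxycarbonyl)amino)ethyl in place of benzyloxycarbonyl giving a number 7.7 percentage points higher from compound 1 to compound 3 (within the scatter), so hydrogen and both large side chains cannot be told apart on this read-out at the one dose given. No measurement is at hand that would explain this result.

As far as these compounds go, what stays open is whether any group at this place can move the number beyond the scatter, for instance a free amine at the end of the chain in place of the tert-butoxycarbonyl-protected amine, or a carboxylic acid in place of the benzyl ester on the side chain. A single dose also leaves open whether these compounds would still match one another at other doses.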